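The source may hold more compounds than are shown below. What is called first, only, known or untested is meant among the compounds shown, and "the series" means these compounds.

Measured so far:
- compound 1, `CC(C)(Oc1ccc([C@H]2CC[C@]3(CC2)OOC2(O3)C3CC4CC(C3)CC2C4)cc1)C(=O)O`: 3.1
- compound 2, `O=C(O)COc1ccc([C@H]2CC[C@]3(CC2)OOC2(O3)C3CC4CC2CC(C3)C4(F)F)cc1`: 2.9
- compound 3, `O=C(O)c1cc([C@H]2CC[C@]3(CC2)OOC2(O3)C3CC4CC(C3)CC2C4)ccc1O`: 3

All three were run in a physicochemical assay for lipophilicity, read by HPLC, at pH 7.4; a higher number here means a more lipophilic compound, a lower number a more polar compound. Compound 1 gives 3.1, and the numbers for compound 3 and compound 2 sit within the scatter of that value, so the three compounds cannot be told apart on this assay.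

Compound 4, `CS(=O)(=O)NC(=O)COc1ccc([C@H]2CC[C@]3(CC2)OOC2(O3)C3CC4CC(C3)CC2C4)cc1`, has not yet been measured. It differs from compound 1 in one place: ((methylsulfonyl)carbamoyl)methyl in place of 1-carboxy-1-methylethyl on an oxygen on an aromatic ring. Among the measured compounds shown here, with no measured pair of this kind to lean on, the step is expected to point downward and to reach somewhat beyond the scatter. Compound 4 is therefore estimated at 2.5, with a range from 1.9 to 3.1, which means an expected step of a number 0.60 log units lower from compound 1 to compound 4 (beyond the scatter).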

Compound 4, distribution coefficient: 3
Compound 4: middle estimate off by 0.50 log units, on the low side; low and high end bracket the measured number.
By their numbers in this assay, from the lowest: compounds 2, 3, 4 and 1 (each within the scatter of the next).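

Among the compounds shown here, this is the first step at this position that can be read directly: on an oxygen on an aromatic ring, ((methylsulfonyl)carbamoyl)methyl in place of 1-carboxy-1-methylethyl gives a number 0.10 log units lower from compound 1 to compound 4 (within the scatter) in this assay. The entering group is larger and has more hydrogen-bond acceptors, yet the two compounds cannot be told apart here. Nothing available explains why they read alike.

Still open, from the compounds shown here alone, is whether a tetrazole or an amine on the same oxygen would also stay within the scatter of compound 1.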